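Swapping the ethylphenyl amide for a furan amide

This account rests on a few compounds, and the source may have more. Where it says the series, first, only, none or still open, it means among the compounds named here.

Compound 1 `Cc1cccc(Cn2c(CN3CCN(C(=O)c4ccc(C(F)(F)F)cc4)CC3)nc3ccccc32)c1`: 22.9%
Compound 2 `Cc1cccc(Cn2c(CN3CCN(C(=O)c4ccncc4)CC3)nc3ccccc32)c1`: 20.6%
Compound 3 `CCc1ccc(C(=O)N2CCN(Cc3nc4ccccc4n3Cc3cccc(C)c3)CC2)cc1`: 67%

In an assay on isolated protein for inhibition of aldehyde dehydrogenase 1A1 (Homo sapiens), read by spectrophotometry, tested at 10 uM (on this read-out lower numbers stand for less inhibition and higher numbers for more inhibition at the one concentration tested (going by the name of the read-out)), compound 3 stands highest of the three numbers, and its nearest neighbour, compound 1, lies beyond the scatter below it. Compound 4 `Cc1cccc(Cn2c(CN3CCN(C(=O)c4ccco4)CC3)nc3ccccc32)c1` differs from compound 3 in one place: furan-2-yl in place of 4-ethylphenyl on a carbonyl carbon. For the measured compounds named here, two measured steps bear on this carbonyl position: a number 46.4 percentage points higher from compound 2 to compound 3 (beyond the scatter) and a number 44.1 percentage points higher from compound 1 to compound 3 (beyond the scatter), both large gains that arrive at the 4-ethylphenyl group. Like pyridin-4-yl in compound 2, furan-2-yl is an aromatic ring with a hetero atom rather than a ring of carbon only, so a reversal of that gain is expected. For compound 4 a large downward step a number 42 percentage points lower from compound 3 to compound 4 (beyond the scatter) is estimated, to about 25% within a range from 10% to 50%.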

Compound 4, a percentage reported as inhibition, at one concentration (the size of the read-out at that concentration, not a potency): 73.2%
Compound 4: the middle estimate sits 48.2 percentage points below what was measured; measured number above the stated range.
By their numbers in this assay, from the lowest: compounds 2 and 1 (each within the scatter of the next); then compounds 3 and 4 (each within the scatter of the next).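

In this assay the step of a number 6.2 percentage points higher from compound 3 to compound 4 (within the scatter) shows that this carbonyl position does not require a ring of carbon only: furan-2-yl and 4-ethylphenyl read alike. A hetero atom in the ring therefore does not by itself mark the low numbers, as the large steps of a number 52.6 percentage points higher from compound 2 to compound 4 (beyond the scatter) and a number 50.3 percentage points higher from compound 1 to compound 4 (beyond the scatter) set furan-2-yl apart from pyridin-4-yl and 4-(trifluoromethyl)phenyl. No measurement here explains this split.

Still open, as far as these compounds go, is whether a thiophen-2-yl ring would match furan-2-yl, and whether a ring is needed at all, which a cyclohexyl group or a simple propyl chain on the carbonyl would test.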